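A few compounds are considered here, and "the series" means these few. Any claim that something is new, unique, unknown or untested is made for them only; others in the source may bear on it.

Measured so far in a functional assay on thoracic aorta (Rattus norvegicus, strain Wistar), with a stated time of 15 min; a higher number here means that more compound is needed for the effect, a lower number that less compound is needed:
compound 1 `CC(C)Oc1ccc(Br)cc1C(C)NC(=O)N(C)S(=O)(=O)c1ccccc1` gives 32100 nM
compound 2 `CCOc1ccc(Cl)cc1C(C)NC(=O)N(C)S(=O)(=O)c1ccccc1` gives 10500 nM
compound 3 `CCOc1ccc(Br)cc1C(C)NC(=O)N(C)S(=O)(=O)c1ccc(Cl)cc1` gives 55700 nM

Compound 3 lies within the usual scatter of compound 1, and its number stands beyond the scatter above that of compound 2. The next compound to be tested is compound 4 `CCOc1ccc(Br)cc1C(C)NC(=O)N(C)S(=O)(=O)c1ccccc1` which differs from compound 3 in a single place: hydrogen in place of chloro on an aromatic carbon with hydrogen in place of chloro on an aromatic carbon, para to a large group, so that 4-chlorophenyl becomes phenyl.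

Going by the values given here, no pair of measured compounds shows this change on its own, so any guidance is indirect. Compound 2 also carries phenyl and gives 10500 nM in this series, while compound 1, again with phenyl, gives 32100 nM here. These two differ elsewhere in the structure as well, and they do not settle the question: one lies within the scatter of compound 3, the other beyond it.

A lower number is expected, and the estimated change is a 2.8-fold lower number from compound 3 to compound 4 (0.44 log units; beyond the scatter) which would be a step modestly beyond the scatter. For compound 4 the estimated value is 20000 nM with an expected range from 8000 nM to 45000 nM in this estimate.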

Compound 4, half-maximal effective concentration: 19800 nM
Compound 4: middle estimate off by 1.0-fold (0.00 log units), on the high side; the measured number falls inside the stated range.
By their numbers in this assay, from the lowest: compounds 2, 4, 1 and 3 (each within the scatter of the next, the first and the last beyond it).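

In this assay, the change from 4-chlorophenyl to phenyl can now be read on its own: hydrogen in place of chloro on an aromatic carbon, para to a large group, gives a 2.8-fold lower number from compound 3 to compound 4 (0.45 log units; beyond the scatter) and so makes a modest difference at this position. Compound 4 also ties the other two phenyl compounds to this step: bromo in place of chloro on an aromatic carbon gives a 1.9-fold higher number from compound 2 to compound 4 (0.28 log units; within the scatter) and hydrogen in place of methyl on a saturated chain carbon gives a 1.6-fold lower number from compound 1 to compound 4 (0.21 log units; within the scatter) so of the three single-place changes, only the loss of chloro goes beyond the scatter. Nothing measured alongside these numbers accounts for that step.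

Going by these compounds, the chloro-to-hydrogen change rests on this single pair, so it remains open whether it would repeat with chloro in place of the bromo of compound 4 or with a longer chain on the oxygen. On these data alone, how the same position would respond to fluoro, methoxy, an amine or a carboxylic acid also remains open.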